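The source may hold more compounds than are shown below. What is called first, only, known or untested is meant among the compounds shown, and "the series" means these compounds.

Of the compounds shown here, three built on one shared core have been tested in a functional assay on MGC-803 cells (Homo sapiens) for antiproliferative activity, read by MTT assay, with a stated time of 48 h; on this read-out higher numbers stand for weaker inhibition and lower numbers for stronger inhibition. Compound 1 `CCOc1ccc(NC(=O)Nc2cccc(CNc3nccnc3Cl)c2)cc1` gives 7240 nM, compound 2 `COc1ccccc1NC(=O)Nc1cccc(CNc2nccnc2Cl)c1` gives 12200 nM, and compound 3 `O=C(Nc1cccc(CNc2nccnc2Cl)c1)NC1CCCC1` gives 23400 nM. Compound 3 thus shows the highest number of the three; the two steps leading up to it are a 1.9-fold higher number from compound 2 to compound 3 (0.28 log units; within the scatter) and a 3.2-fold higher number from compound 1 to compound 3 (0.51 log units; beyond the scatter).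

Compound 4 `O=C(Nc1cccc(CNc2nccnc2Cl)c1)Nc1ccc(Cl)cc1Br` is not yet measured. Its structural difference from compound 3 is 2-bromo-4-chlorophenyl in place of cyclopentyl on an amide-type nitrogen. Going by the values given here, two measured steps bear on this change, both running the other way: a 3.2-fold higher number from compound 1 to compound 3 (0.51 log units; beyond the scatter) and a 1.9-fold higher number from compound 2 to compound 3 (0.28 log units; within the scatter). Reversing them, putting an aromatic ring back in place of the cyclopentyl group is expected to lower the number by a modest amount, most likely at the edge of the scatter or somewhat beyond it.

Compound 4 is therefore estimated to give 9000 nM in this assay, within a range from 3500 nM to 22000 nM. This estimate corresponds to an expected step of a 2.6-fold lower number from compound 3 to compound 4 (0.41 log units; beyond the scatter).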

Compound 4, half-maximal inhibitory concentration: 7480 nM
Compound 4: the middle estimate sits 1.2-fold (0.08 log units) above what was measured, and the stated range covers the measured number.
By their numbers in this assay, from the lowest: compounds 1, 4, 2 and 3 (each within the scatter of the next, the first and the last beyond it).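

On the amide-type nitrogen, 2-bromo-4-chlorophenyl in place of cyclopentyl gives a 3.1-fold lower number from compound 3 to compound 4 (0.50 log units; beyond the scatter) in this assay, so an aromatic ring carrying two halogens, rather than the oxygen-linked groups of the earlier rings, also goes with a lower number than the cyclopentyl group. Against the two earlier aromatic rings, the change gives a 1.6-fold lower number from compound 2 to compound 4 (0.21 log units; within the scatter) and a 1.0-fold higher number from compound 1 to compound 4 (0.01 log units; within the scatter), and since both steps lie within the scatter, swapping 2-methoxyphenyl or 4-ethoxyphenyl for this halogen-bearing ring makes no readable difference at this position. Nothing measured here accounts for the step away from cyclopentyl.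

From the compounds shown here alone, it remains open whether a plain phenyl ring would give a similar number, or whether bromine or chlorine alone would do so. A carboxylic acid or an amine on the ring is also untested among the compounds shown.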